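Moving one chlorine around an aryl ring

The source may hold more compounds than are shown below. What is called first, only, known or untested is meant among the compounds shown, and "the series" means these compounds.

Compound 1, `NC(=O)c1c(N)[nH]c(C(=O)c2ccccc2)c1-c1ccc(Cl)cc1Cl`, gives > 100000 nM in an assay for inhibition of Polyunsaturated fatty acid lipoxygenase ALOX15 (Homo sapiens), with a stated time of 10 min; a higher number here means a weaker inhibitor, a lower number a stronger inhibitor; this is a limit of the assay, not a number.
Compound 2, `Nc1[nH]c(C(=O)c2ccccc2)c(-c2ccccc2Cl)c1C(=O)c1cccc(Cl)c1`, gives > 100000 nM in this assay; this too is a limit, not a number.
Compound 3, `Nc1[nH]c(C(=O)c2ccccc2)c(-c2ccc(Cl)cc2Cl)c1C(=O)c1cccs1`, gives > 100000 nM in this assay; again a limit, not a number.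

Compound 2 therefore stands only at a limit, as do the two other values shown. Within the data shown here, the single measured step, a step that the two limits leave unreadable from compound 1 to compound 3, has no readable size because the limit of > 100000 nM in this assay, at which 3 of the 3 values shown sit, covers both of its ends. Compound 4, `Nc1[nH]c(C(=O)c2ccccc2)c(-c2ccc(Cl)cc2)c1C(=O)c1cccc(Cl)c1`, differs from compound 2 by 4-chlorophenyl in place of 2-chlorophenyl on an aromatic carbon. Among the measured compounds shown here, no measured step touches this change, and the one step that exists gives no size at all, so there is no basis for expecting a move in either direction beyond the scatter. The expected step of a number no higher from compound 2 to compound 4 (the limit leaves the size open) is accordingly none beyond the scatter. Compound 4 is estimated to give 100000 nM in this assay, with a range from 30000 nM to 300000 nM, and most likely only a limit again.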

Compound 4, half-maximal inhibitory concentration: > 100000 nM
Compound 4: no number, only a limit; the forecaster's own chance of this, stated with the estimate: 80%; the middle value lies on the limit itself.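

Swapping 2-chlorophenyl for 4-chlorophenyl gives no readable step between compound 2 and compound 4, because each of the two stands only at a limit, not a number: the limit of > 100000 nM in this assay, at which 4 of the 4 values shown sit.

The compounds shown leave open whether moving this chlorine changes anything in this assay, as none of them gives a measured number there.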